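A few compounds are considered here, and "the series" means these few. Any claim that something is new, unique, unknown or untested is made for them only; others in the source may bear on it.

Series notes. Within the data shown here, compound 2 `Cc1cc(-c2c(C)n[nH]c2C)ccc1-c1nnc(N(C)Cc2ccc3nccn3c2)o1` is the reference point for the step under consideration; in an assay on COS-7 cells for inhibition of tyrosine-protein kinase receptor UFO (Homo sapiens), read by ELISA, with a stated time of 1 h (on this read-out higher numbers stand for weaker inhibition and lower numbers for stronger inhibition), compound 2 gives 15800 nM, the only numerical value in the set. Compound 1 `Cc1nn(C)c(C)c1-c1ccc(-c2nnc(N(C)Cc3ccc4nccn4c3)o2)c(C#N)c1` is a related analogue that differs from compound 2 in more than one place. In this assay compound 1 returns only a limit, > 31600 nM. Among the measured compounds shown here, with no single-point step between compound 1 and compound 2, their values stand side by side without comparison; the only evidence on the measured side is the limit of > 31600 nM in this assay, at which 1 of the 2 values shown sits. Compound 3 `Cc1cc(-c2c(C)nn(C(F)F)c2C)ccc1-c1nnc(N(C)Cc2ccc3nccn3c2)o1` is the unmeasured member: difluoromethyl in place of hydrogen on an aromatic nitrogen. For the measured compounds named here, no measured step of this kind exists, so the expectation rests on the value of compound 2 alone. The step from compound 2 to compound 3 is expected to be small, nothing beyond the usual scatter, a 1.3-fold higher number from compound 2 to compound 3 (0.10 log units; within the scatter). Compound 3 is therefore estimated at 20000 nM, within 7000 nM to 50000 nM, with a fair chance that this assay again reports only a limit.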

Compound 3, half-maximal inhibitory concentration: > 10000 nM
Compound 3: a limit, no number (the forecaster's own chance of this, stated with the estimate: 40%); the middle value lies beyond the limit too.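

In this assay, among these compounds, compound 3 returns > 10000 nM, a limit and not a number, so no step from compound 2 to compound 3 can be read. Going by these compounds, whether difluoromethyl in place of hydrogen on an aromatic nitrogen shifts the read-out at all stays open.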